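Compound 1 to compound 4: a side-chain exchange

A few compounds are considered here, and "the series" means these few. Any claim that something is new, unique, unknown or untested is made for them only; others in the source may bear on it.

Among the compounds with values here, in a toxicity assay on HEK-293T cells (Homo sapiens) for cytotoxicity, read by MTT assay, with a stated time of 72 h (on this read-out lower numbers stand for stronger inhibition and higher numbers for weaker inhibition), compound 1 (`O=C1c2c[n+]([O-])c3ccccc3c2C(=O)c2c1c1ccccc1n2CCCCn1ccnc1`) gives 280 nM, the lowest of the three numbers so far. Compound 2 (`O=C1c2c[n+]([O-])c3ccccc3c2C(=O)c2c1c1ccccc1n2Cc1cn([C@@H]2C[C@H](O)[C@@H](CO)O2)nn1`) gives 820 nM and compound 3 (`CC1(C)OCC(Cn2cc(Cn3c4c(c5ccccc53)C(=O)c3c[n+]([O-])c5ccccc5c3C4=O)nn2)O1`) gives 5510 nM. Compound 4 (`O=C1c2c[n+]([O-])c3ccccc3c2C(=O)c2c1c1ccccc1n2Cc1cn(CC(O)CO)nn1`) keeps the core of compound 1, and the change is 1-(2,3-dihydroxypropyl)-1H-1,2,3-triazol-4-yl in place of 3-(1H-imidazol-1-yl)propyl on a saturated chain carbon bound to an aromatic nitrogen on a saturated chain carbon bound to an aromatic nitrogen.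

Within the data shown here, no measured step covers this exchange directly. The closest evidence is a 6.7-fold higher number from compound 2 to compound 3 (0.83 log units; beyond the scatter) when (2,2-dimethyl-1,3-dioxolan-4-yl)methyl replaces 4-hydroxy-5-(hydroxymethyl)oxolan-2-yl on an aromatic nitrogen. Compound 4 shares the triazole ring of compounds 2 and 3, and both of those sit above compound 1 in the numbers. Its free hydroxy groups resemble compound 3 less than compound 2, so a value nearer 820 nM is expected. The expected change is a modest rise beyond the scatter, estimated as a 5.4-fold higher number from compound 1 to compound 4 (0.73 log units; beyond the scatter) in this assay. For compound 4 the estimated value is 1500 nM (expected range 500 nM to 5000 nM).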

Compound 4, half-maximal inhibitory concentration: 760 nM
Beside the measured number, compound 4's estimate is 2.0-fold (0.30 log units) above it, within the range that was stated.
By their numbers in this assay, from the lowest: compound 1; then compounds 4 and 2 (each within the scatter of the next); then compound 3.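

In this assay, the step of a 7.3-fold lower number from compound 3 to compound 4 (0.86 log units; beyond the scatter) lies beyond the scatter and comes with 1,2-dihydroxyethyl in place of 2,2-dimethyl-1,3-dioxolan-4-yl on a saturated chain carbon bound to an aromatic nitrogen, so the number at this position responds to that exchange on the triazole side chain. By contrast, the step of a 1.1-fold lower number from compound 2 to compound 4 (0.03 log units; within the scatter) lies within the scatter, so 2,3-dihydroxypropyl and 4-hydroxy-5-(hydroxymethyl)oxolan-2-yl on an aromatic nitrogen cannot be told apart here. Within the data shown here, the step of a 2.7-fold higher number from compound 1 to compound 4 (0.43 log units; beyond the scatter) is beyond the scatter, and it is the first measured link between the imidazole and triazole side chains.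

Nothing shown accounts for these steps. As far as these compounds go, the exchange alters ring and chain together, so an imidazole on a shorter chain, or a triazole carrying an amine, remains open.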